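The source may hold more compounds than are shown below. What is called first, only, known or untested is meant among the compounds shown, and "the series" means these compounds.

Measured so far:
compound 1 `c1ccc2c(c1)CN[C@@H](CN(CCCN1CCNCC1)[C@H]1CCCc3cccnc31)C2` gives 100% in an ADME assay on microsomes from liver (Rattus norvegicus) for metabolic stability, read by LC-MS, with a stated time of 10 min, tested at 0.5 uM; on this read-out higher numbers stand for a more stable compound and lower numbers for a less stable compound
compound 2 `c1cnc2c(c1)CN[C@@H](CN(CCCN1CCNCC1)[C@H]1CCCc3cccnc31)C2` gives 79% in this assay

Compound 2 holds the lower of the two numbers. Compound 3 `c1cnc(CN(CCCN2CCNCC2)[C@H]2CCCc3cccnc32)nc1` is unmeasured and carries this change from compound 2 (a group of 6 heavy atoms (4 carbon, 2 nitrogen; one six-membered aromatic ring with 2 hetero atoms) in place of a group of 10 heavy atoms (8 carbon, 2 nitrogen; one six-membered non-aromatic ring with 1 hetero atom, one six-membered aromatic ring with 1 hetero atom), on a saturated chain carbon bound to an amine nitrogen). For the measured compounds named here, one measured step bears on it (a number 21 percentage points lower from compound 1 to compound 2 (beyond the scatter)) and there the aromatic ring of the group went from carbon only to 1 hetero atom. Going by the values given here, the pyrimidin-2-yl group has 2 hetero atoms in that ring, but no measured step removes the non-aromatic ring, so the guide is only partial. A modest drop is expected in this assay and the estimated step is a number 14 percentage points lower from compound 2 to compound 3 (beyond the scatter) in size. Compound 3 is estimated at 65% (expected range 40% to 90%).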

Compound 3, percent of the compound remaining: 68%
Beside the measured number, compound 3's estimate is 3 percentage points below it; the range from low to high includes it.
By their numbers in this assay, from the lowest: compound 3; then compound 2; then compound 1.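

For the compounds shown here, at this saturated chain carbon bound to an amine nitrogen, the step of a number 11 percentage points lower from compound 2 to compound 3 (beyond the scatter) in this assay is the first to remove the non-aromatic ring, and the ring left carries 2 hetero atoms. Pyrimidin-2-yl in place of 1,2,3,4-tetrahydroisoquinolin-3-yl gives a number 32 percentage points lower from compound 1 to compound 3 (beyond the scatter) and is the largest step in the series so far. No measurement on hand gives a cause for either step.

Loss of the non-aromatic ring and the change in aromatic hetero atoms remain unseparated here. A phenyl or a pyridin-2-yl group at this place would bear on that.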